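Cyano in place of methyl: expected tolerance of compound 4

The compounds below may be only part of what the source reports. "The series", "measured", "known", "first", "only" and "open" are said of these compounds alone.

Compound 1 `CC(C)=CCOc1cc(Nc2nccs2)ccc1C` gives 17000 nM in a functional assay on MT2 cells (Homo sapiens) for cytotoxicity (a higher number here means that more compound is tolerated, a lower number that less compound is tolerated), the higher of the two numbers reported, though its gap to compound 3 `COc1ccnc(Nc2ccc(Cl)c(OCC=C(C)C)c2)n1`, which gives 9000 nM, lies within the scatter. Compound 2 `CC(C)=CCOc1cc(Nc2nccc(C)n2)ccc1Cl` is reported only as a limit, < 200 nM, that is the limit of < 200 nM in this assay, at which 1 of the 3 values shown sits. Going by the values given here, the single measured step, an at least 45-fold higher number from compound 2 to compound 3 (1.65 log units; beyond the scatter), is large but concerns a different group at a different place. Compound 4 `CC(C)=CCOc1cc(Nc2nccs2)ccc1C#N` differs from compound 1 by cyano in place of methyl on an aromatic carbon. Among the compounds with values here, no measured step bears on this change, so no step beyond the scatter is expected in this assay. Compound 4 is therefore estimated at 15000 nM, with a range from 5000 nM to 45000 nM, an expected step of a 1.1-fold lower number from compound 1 to compound 4 (0.05 log units; within the scatter).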

Compound 4, half-maximal cytotoxic concentration: 500 nM
Compound 4: middle estimate off by 30-fold (1.48 log units), on the high side, outside the stated range (below it).
By their numbers in this assay, from the lowest: compound 4; then compounds 3 and 1 (each within the scatter of the next). At a limit, below all of these: compound 2.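

At this position, ortho to a (3-methylbut-2-en-1-yl)oxy group and para to a (1,3-thiazol-2-yl)amino group, the substituent matters in this assay: cyano in place of methyl brings a 34-fold lower number from compound 1 to compound 4 (1.53 log units; beyond the scatter). Going by these compounds alone, the only earlier step lay at a different place. Nothing at hand accounts for this step.

Going by these compounds, whether the change belongs to the cyano group specifically remains open, as does how a carboxamide or a carboxylic acid at this position would read in this assay. On these data alone, whether the step carries over to the cores of compound 2 and compound 3 is also open.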